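Methoxy added to an indole chalcone

A few compounds are considered here, and "the series" means these few. Any claim that something is new, unique, unknown or untested is made for them only; others in the source may bear on it.

Measured so far:
compound 1 `O=C(/C=C/c1c[nH]c2ccccc12)c1ccccn1`: 53%
compound 2 `O=C(/C=C/c1c[nH]c2ccccc12)c1ccncc1`: 22%

In a functional assay on U-251 cells (Homo sapiens) for inhibition, read by colony formation, with stated times of 48 h and 2 weeks, tested at 10 uM (on this read-out lower numbers stand for less inhibition and higher numbers for more inhibition at the one concentration tested (going by the name of the read-out)), compound 1 gives 53%, whereas compound 2 gives 22%, the lower of the two numbers. For the measured compounds named here, the only measured step, a number 31 percentage points lower from compound 1 to compound 2 (beyond the scatter), moves the nitrogen within the ring attached to the carbonyl; it says nothing about the other end of the molecule.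

Compound 3 `COc1ccc2[nH]cc(/C=C/C(=O)c3ccncc3)c2c1` differs from compound 2 by methoxy in place of hydrogen on an aromatic carbon. Going by the values given here, no measured pair touches this ring, so there is no step to lean on. Without such a precedent the safest expectation is a change no larger than the scatter, in either direction. The estimate for compound 3 is therefore close to compound 2, with the step of a number 3 percentage points higher from compound 2 to compound 3 (within the scatter) expected to stay within the usual spread. Compound 3 is expected to give 25%, with a range from 5% to 50%.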

Compound 3, a percentage reported as inhibition, at one concentration (the size of the read-out at that concentration, not a potency): 2%
Compound 3: middle estimate off by 23 percentage points, on the high side, outside the stated range (below it).
By their numbers in this assay, from the lowest: compound 3; then compound 2; then compound 1.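

This aromatic carbon, meta to one fused ring and para to another, is not a silent place on the molecule: in this assay the swap of hydrogen for methoxy gives a number 20 percentage points lower from compound 2 to compound 3 (beyond the scatter) and so lowers inhibition at the one concentration tested. The earlier pair varied only the ring on the carbonyl, whereas this step shows that the other end of the molecule also moves the number. A group of just 2 heavy atoms is enough for a step beyond the usual scatter, although no measurement here explains it.

Still open, on these data alone, is whether methoxy at this carbon would also lower the number for compound 1, with its pyridin-2-yl ring. As far as these compounds go, it is equally open whether a hydroxyl, a chlorine or an amine at the same carbon would go the same way.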